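A few compounds are considered here, and "the series" means these few. Any claim that something is new, unique, unknown or untested is made for them only; others in the source may bear on it.

Compound 1 `CN(CC1CCN(CCCc2c[nH]c3ccc(-n4cnnc4)cc23)CC1)C(=O)Nc1ccccc1` gives 5.9 nM in an assay on CHO cells for displacement of a labelled ligand from 5-hydroxytryptamine receptor 1D (Homo sapiens) (a lower number here means a stronger inhibitor, a higher number a weaker inhibitor), the second highest of the three numbers shown. Compound 2 `c1ccc2c(c1)CCC2NC1CCN(CCCc2c[nH]c3ccc(-n4cnnc4)cc23)CC1` gives 8.9 nM, which lies within the scatter of compound 1, while compound 3 `CN(Cc1ccsc1)C1CCN(CCCc2c[nH]c3ccc(-n4cnnc4)cc23)CC1` gives 1.5 nM, a number beyond the scatter below compound 1. For the measured compounds named here, the only measured step, a 5.9-fold lower number from compound 2 to compound 3 (0.77 log units; beyond the scatter), concerns a group on a saturated ring carbon rather than the chain carbon that is changed here. Compound 4 `CC(=O)Nc1ccc(CNCC2CCN(CCCc3c[nH]c4ccc(-n5cnnc5)cc34)CC2)cc1` differs from compound 1 in one place: (4-acetamidobenzyl)amino in place of methyl(phenylcarbamoyl)amino on a saturated chain carbon bound to a saturated ring carbon. Going by the values given here, no measured step bears directly on this change, so the expectation rests on compound 1 alone. Compound 4 is expected to give 6 nM, within a range of 2 nM to 18 nM. That estimate means a 1.0-fold higher number from compound 1 to compound 4 (0.01 log units; within the scatter), a step expected to stay within the scatter.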

Compound 4, half-maximal inhibitory concentration: 4.2 nM
For compound 4 the middle estimate is 1.4-fold (0.15 log units) above the measured one; the measured number falls inside the stated range.
By their numbers in this assay, from the lowest: compound 3; then compounds 4, 1 and 2 (each within the scatter of the next, the first and the last beyond it).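

In this assay, for the compounds shown here, the step of a 1.4-fold lower number from compound 1 to compound 4 (0.15 log units; within the scatter) gives the first reading at a saturated chain carbon bound to a saturated ring carbon, where the earlier step concerned only a saturated ring carbon. At this position, (4-acetamidobenzyl)amino and methyl(phenylcarbamoyl)amino lie within the scatter of each other, although the two groups differ in structure. Nothing available explains this result. Going by these compounds, it remains open whether a plain amine or a carboxylic acid on this chain carbon would stay within the scatter of these two groups.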